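Taking the hydroxy group away from compound 2

This account rests on a few compounds, and the source may have more. Where it says the series, first, only, none or still open, it means among the compounds named here.

In a functional assay on NCI-H460 cells (Homo sapiens) for antiproliferative activity, read by sulforhodamine B assay, with a stated time of 48 h (a lower number here means a stronger inhibitor of growth, a higher number a weaker inhibitor of growth), compound 1 `CCCCCC[C@@H](O)C/C=C\CCCCCCCC(=O)N[C@@H](C)c1ccccc1` gives 8.3 ug/mL and compound 2 `CCCCCC[C@@H](O)C/C=C\CCCCCCCC(=O)N1CCOCC1` gives 49.1 ug/mL, so compound 2 holds the higher of the two numbers and is the weaker growth inhibitor of the pair. For the measured compounds named here, the only measured step, a 5.9-fold higher number from compound 1 to compound 2 (0.77 log units; beyond the scatter), puts morpholin-4-yl in place of (1-phenylethyl)amino on a carbonyl carbon. Compound 3 `CCCCCCCC/C=C\CCCCCCCC(=O)N1CCOCC1` keeps that morpholin-4-yl group and differs from compound 2 elsewhere: hydrogen in place of hydroxy on a saturated chain carbon bound to two saturated chain carbons. Here hydrogen stands in place of hydroxy on a saturated chain carbon bound to two saturated chain carbons. Going by the values given here, no measured step touches this place, so the step from compound 1 offers no guide to its size or direction. With nothing to suggest otherwise, no change beyond the scatter is expected in this assay, and the starting point is compound 2 at 49.1 ug/mL. The expected step is a 1.2-fold lower number from compound 2 to compound 3 (0.07 log units; within the scatter). For compound 3 the estimated value is 42 ug/mL, with an expected range of 18 ug/mL to 95 ug/mL.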

Compound 3, concentration for 50% growth inhibition: 7.9 ug/mL
Compound 3: the middle estimate sits 5.3-fold (0.73 log units) above what was measured; the whole stated range lies above it.
By their numbers in this assay, from the lowest: compounds 3 and 1 (each within the scatter of the next); then compound 2.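

In this assay the change to hydrogen in place of hydroxy on a saturated chain carbon bound to two saturated chain carbons brings a 6.2-fold lower number from compound 2 to compound 3 (0.79 log units; beyond the scatter) and so shows that this chain position also bears on the number, which the earlier step at the carbonyl carbon could not show. With the morpholin-4-yl group held fixed, the compound without the hydroxy is the stronger growth inhibitor of the pair, so in this amide the hydroxy is not needed for activity. Nothing at hand explains this step.

The compounds shown leave open how the same change reads with the (1-phenylethyl)amino group of compound 1. They also leave open whether a methoxy group, a ketone or an amine at this chain carbon would read like the hydroxy or like the hydrogen.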